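The compounds below may be only part of what the source reports. "The series", "measured", "known", "first", "only" and "open" are said of these compounds alone.

Compound 1 `O=C1/C(=C\c2ccc(O)cc2)c2ccccc2N1c1c(Cl)cccc1Cl` is the starting point of this comparison. For the measured compounds named here, in a functional assay on HuTu80 cells (Homo sapiens) for cytotoxicity, read by MTT assay, with a stated time of 72 h (on this read-out lower numbers stand for an effect already at smaller amounts and higher numbers for an effect only at larger amounts of compound), compound 1 gives 25 ug/mL, and this is the only plain number among the three compounds with a reported result. Compound 2 `Cc1ccc2nc(Cl)c(/C=C3\C(=O)N(c4c(Cl)cccc4Cl)c4ccccc43)cc2c1` shares the same core but carries a different aromatic group on the double bond; in this assay compound 2 has "not determined" (no result reported). Compound 3 `COc1ccc(/C=C2\C(=O)N(c3c(Cl)cccc3Cl)c3ccccc32)cc1OC` reached only a limit of the assay: in this assay compound 3 gives < 1 ug/mL, which is the limit of < 1 ug/mL in this assay, at which 1 of the 3 values shown sits. So no step between two measured numbers can be sized, and no pattern among the measured compounds can be claimed.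

Compound 4 `CN(C)c1ccc(/C=C2\C(=O)N(c3c(Cl)cccc3Cl)c3ccccc32)cc1` differs from compound 1 in one place: dimethylamino in place of hydroxy on an aromatic carbon. The exchange sits on an aromatic carbon of a six-membered aromatic ring of carbon only, para to a large group, where the hydroxy of compound 1 stood.

Going by the values given here, with no measured step available, the expectation rests on compound 1 at 25 ug/mL. Compound 3, on the same core, gives < 1 ug/mL in this assay, which is a limit of the assay. The step from compound 1 to compound 4 is expected to run toward smaller amounts, a 5.0-fold lower number from compound 1 to compound 4 (0.70 log units; beyond the scatter), beyond the usual scatter. For compound 4 the estimate is 5 ug/mL, with a range from 1 ug/mL to 25 ug/mL.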

Compound 4, concentration for half-maximal effect: < 1 ug/mL
Compound 4 ended at the assay's limit (the forecaster's own chance of this, stated with the estimate: 15%); at least 5.0-fold (0.69 log units) between middle value and limit.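

For the compounds shown here, exchanging hydroxy for dimethylamino on an aromatic carbon, para to a large group, gives the first step that can be sized on the shared core: an at least 25-fold lower number from compound 1 to compound 4 (1.39 log units; beyond the scatter). Going by these compounds alone, this large step shows that the result in this assay depends strongly on what this one place carries, which the earlier compounds could not show because no two of them formed a readable single change. In this assay, from the compounds shown here alone, compound 4 gives < 1 ug/mL, which is a limit of the assay, so the step fixes only a smallest size and the full size stays unknown.

The compounds shown leave open whether the result follows the loss of hydroxy or the arrival of dimethylamino, since one exchange does both at once. A plain amino group, a diethylamino group or a carboxylic acid at this same place would help separate those two readings, provided their values fall clear of the limit of the assay.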